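A Ring Nitrogen Shift and Expected Paw Edema Inhibition

A few compounds are considered here, and "the series" means these few. Any claim that something is new, unique, unknown or untested is made for them only; others in the source may bear on it.

Compound 1 `O=C(N/N=C/c1ccccc1)c1cccnc1Nc1cccc(C(F)(F)F)c1` is the starting point. Among the compounds with values here, in a functional assay on the whole organism (strain Wistar) for inhibition, with Rattus norvegicus as the target, read by paw edema, with a stated time of 3 h, at a dose of 10 mg/kg by the intraperitoneal route (on this read-out higher numbers stand for more inhibition at the one dose given (going by the name of the read-out) and lower numbers for less inhibition), compound 1 gives 21.2%, the lower of the two numbers measured so far. Within the data shown here, its only measured neighbour is compound 2 `O=C(N/N=C/c1cccnc1)c1cccnc1Nc1cccc(C(F)(F)F)c1`, in which a pyridin-3-yl stands in place of the phenyl on the carbon with a double bond to nitrogen; in this assay compound 2 gives 52.4%, and the step is a number 31.2 percentage points higher from compound 1 to compound 2 (beyond the scatter).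

Compound 3 `O=C(N/N=C/c1ccncc1)c1cccnc1Nc1cccc(C(F)(F)F)c1` has not yet been measured. It differs from compound 1 by pyridin-4-yl in place of phenyl on a carbon with a double bond to nitrogen. Among the measured compounds shown here, the one measured step that bears on this change is the one where a number 31.2 percentage points higher from compound 1 to compound 2 (beyond the scatter), a case in which a pyridin-3-yl rather than a pyridin-4-yl entered the same place. For the measured compounds named here, because of that step, a rise in this assay is expected for compound 3 as well, though with only one related example the size is uncertain and a somewhat smaller gain is assumed. Compound 3 is therefore estimated to give 44%, with a range from 24% to 64%. This expected outcome corresponds to an estimated step of a number 22.8 percentage points higher from compound 1 to compound 3 (beyond the scatter).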

Compound 3, a percentage reported as inhibition, in the whole organism at one dose (the size of the read-out at that dose, not a potency): 54.9%
The estimate for compound 3 lay 10.9 percentage points below the measured number; measured number inside the range.
By their numbers in this assay, from the lowest: compound 1; then compounds 2 and 3 (each within the scatter of the next).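

In this assay, replacing phenyl with pyridin-4-yl on the carbon with a double bond to nitrogen gives a number 33.7 percentage points higher from compound 1 to compound 3 (beyond the scatter), so the large gain seen with pyridin-3-yl is no longer a single case: two different rings with one ring nitrogen both stand clear of the phenyl ring. Comparing those two rings directly gives a number 2.5 percentage points higher from compound 2 to compound 3 (within the scatter), which means that this assay cannot tell them apart. Among the compounds shown, then, this position responds to the change from an all-carbon ring to either pyridine ring, while the choice between pyridin-3-yl and pyridin-4-yl makes no difference that can be read, and no compound here goes against that pattern.

Nothing measured here explains why the two pyridine rings give the higher numbers, and a single dose at a single time gives no potency for any of the three compounds. Also open, on these data alone, is how pyridin-2-yl, or a phenyl ring carrying an amine or a carboxylic acid, would behave at this same place.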